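Swapping methyl for 2-oxopyrrolidin-1-yl on compound 1

The source may hold more compounds than are shown below. What is called first, only, known or untested is meant among the compounds shown, and "the series" means these compounds.

Compound 1 `Cc1ccc(S(=O)(=O)N2C(=O)COC23C=CC(=O)C=C3)cc1` gives 70 nM
Compound 2 `N#Cc1cccc(S(=O)(=O)N2C(=O)COC23C=CC(=O)C=C3)c1` gives > 10000 nM

Among the measured compounds shown here, in a functional assay on MDA-MB-231 cells (Homo sapiens) for inhibition, read by sulforhodamine B assay, with a stated time of 74 h (a lower number here means a stronger inhibitor, a higher number a weaker inhibitor), compound 1 gives 70 nM as the only exact number so far. Compound 2 gives > 10000 nM which is a limit of the assay and not a number. Compound 3 `O=C1C=CC2(C=C1)OCC(=O)N2S(=O)(=O)c1ccc(N2CCCC2=O)cc1` keeps the core of compound 1 but carries 2-oxopyrrolidin-1-yl in place of methyl on an aromatic carbon, para to a large group (2-oxopyrrolidin-1-yl in place of methyl on an aromatic carbon). For the measured compounds named here, no measured step shows what this change does, so the forecast is loose. A moderate weakening is expected, estimated as a 4.3-fold higher number from compound 1 to compound 3 (0.63 log units; beyond the scatter) in this assay for this change. Compound 3 is expected at 300 nM within an estimated range of 50 nM to 3000 nM for this measurement.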

Compound 3, half-maximal inhibitory concentration: > 10000 nM
Compound 3: only a limit was reported (the forecaster's own chance of this, stated with the estimate: 10%); middle value at least 33-fold (1.52 log units) from the limit.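

In this assay, putting 2-oxopyrrolidin-1-yl in place of methyl gives an at least 140-fold higher number from compound 1 to compound 3 (2.15 log units; beyond the scatter), so this position on the aromatic ring does not accept every group that replaces methyl. Compound 3 has only a limit of the assay and not a number, so the true size of this step stays unknown: the limit of > 10000 nM in this assay, at which 2 of the 3 values shown sit.

The compounds shown leave open which part of 2-oxopyrrolidin-1-yl goes with the loss. An ethyl group, a methoxy group or an open-chain acetamide at this position would help to separate the ring from its carbonyl.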